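The compounds below may be only part of what the source reports. "The series", "measured", "known", "first", "only" and "open" are said of these compounds alone.

Of the compounds shown here, two have been measured in an assay on membranes from HEK293 cells for displacement of a labelled ligand from adenosine receptor A2b (Homo sapiens), read by scintillation counting, with a stated time of 30 min, tested at 1 uM; a higher number here means more inhibition at the concentration tested (going by the name of the read-out), a lower number less inhibition. Compound 1 `CCCC(=O)C1=C(C)NC(=O)NC1c1cccs1` gives 9% in this assay. Compound 2 `CC1=C(C(=O)C2CC2)C(c2ccsc2)NC(=O)N1` gives 1% in this assay. Of the two numbers, that of compound 2 is the smaller, but its distance to compound 1 lies within the usual scatter of repeated measurements, so the two compounds cannot be told apart; both show little inhibition at the concentration tested.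

Compound 3 `CCCC(=O)C1=C(C)NC(=O)NC1c1ccsc1` has not been measured. It differs from compound 2 in one place: propyl in place of cyclopropyl on a carbonyl carbon. Going by the values given here, no measured pair carries this change, so its size is not known from the data. With both measured compounds sitting near the bottom of the read-out in this assay, a step of a number 4 percentage points higher from compound 2 to compound 3 (within the scatter) is expected, which is none beyond the scatter. Compound 3 is accordingly estimated at 5% in this assay, within a range of 0% to 15%.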

Compound 3, a percentage reported as inhibition, at one concentration (the size of the read-out at that concentration, not a potency): 9%
The estimate for compound 3 lay 4 percentage points below the measured number; the measured number falls inside the stated range.
By their numbers in this assay, from the lowest: compounds 2, 1 and 3 (each within the scatter of the next).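

In this assay the series now holds its first pair for the change at this position: propyl in place of cyclopropyl on a carbonyl carbon gives a number 8 percentage points higher from compound 2 to compound 3 (within the scatter) and so, with these two compounds, removing the three-membered ring from this carbonyl substituent does not shift the read-out beyond the scatter. The second pair adds a different place, as thiophen-3-yl in place of thiophen-2-yl on a saturated ring carbon gives no change at the digits printed from compound 1 to compound 3 (within the scatter) and so, with the propylcarbonyl group held constant, the two thiophene attachments cannot be told apart. No measured evidence bears on these results, and no explanation can be drawn from them.

Open, from the compounds shown here alone, is whether another group on the carbonyl carbon, such as a longer chain or an amine-bearing chain, or a phenyl or pyridine ring on the saturated ring carbon in place of thiophene, would move the number in this assay beyond the scatter. With both steps within the scatter at a single concentration, the compounds shown do not tell whether either place on the shared core can change the inhibition at all.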